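The compounds below may be only part of what the source reports. "The series", "measured", "known", "first", "only" and "open" are said of these compounds alone.

The measured compounds:

compound 1, `O=[N+]([O-])c1cn2c(n1)OC(COc1ccc(-c3ccc(C(F)(F)F)cc3)cn1)C2`, 45000 nM
compound 2, `O=[N+]([O-])c1cn2c(n1)OC(COc1ccc(-c3ccc(OC(F)(F)F)cc3)cn1)C2`, 47000 nM
compound 3, `CC1(COc2ccc(-c3ccc(C(F)(F)F)cc3)cc2)Cn2cc([N+](=O)[O-])nc2O1`, limit only

The three were examined in an ADME assay on MRC5 cells (Homo sapiens) for cytotoxicity, read by fluorescence, with a stated time of 72 h; a higher number here means a weaker inhibitor, a lower number a stronger inhibitor. Compound 1 and compound 2 share a core and differ in a single place: trifluoromethoxy in place of trifluoromethyl on an aromatic carbon. The measured step is a 1.0-fold higher number from compound 1 to compound 2 (0.02 log units; within the scatter), so the two values lie within the ordinary scatter of such experiments and no order between them can be read. For compound 3 the assay reports only a limit, > 64000 nM, and not a number; this is the limit of > 64000 nM in this assay, at which 1 of the 3 values shown sits. How the core of compound 3 differs from the core of compound 1 is not broken down here.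

The unmeasured compound 4, `CC1(COc2ccc(-c3ccc(OC(F)(F)F)cc3)cc2)Cn2cc([N+](=O)[O-])nc2O1`, stands to compound 3 as compound 2 stands to compound 1: trifluoromethoxy in place of trifluoromethyl on an aromatic carbon. The place description is the same word for word in both pairs, so this is the same change made on a different core.

In this assay the expected step is a step that the limit leaves unreadable from compound 3 to compound 4. That expectation rests on the step of a 1.0-fold higher number from compound 1 to compound 2 (0.02 log units; within the scatter), which was within the scatter, and on the fact that compound 3 itself gave only a limit. Compound 4 is therefore estimated at 70000 nM, with a plausible range from 40000 nM to 130000 nM, and a limit rather than a number is the more likely report.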

Compound 4, half-maximal inhibitory concentration: > 64000 nM
Compound 4: no number, only a limit; the forecaster's own chance of this, stated with the estimate: 70%; the middle value does not contradict the limit.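

In this assay compound 4 gives > 64000 nM, which is a limit and not a number. Compound 3 also gave only a limit, so no step can be read from compound 3 to compound 4: the limit of > 64000 nM in this assay, at which 2 of the 4 values shown sit.

The compounds shown leave open whether trifluoromethoxy in place of trifluoromethyl on an aromatic carbon makes any difference on the core of compound 3.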